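Phenoxy in place of hydroxy on the benzylamine arm

The compounds below may be only part of what the source reports. "The series", "measured", "known", "first", "only" and "open" are said of these compounds alone.

In a functional assay for agonist activity at Free fatty acid receptor 1 (Homo sapiens) (on this read-out higher numbers stand for an effect only at larger amounts of compound and lower numbers for an effect already at smaller amounts), compound 1 `O=C(O)CCc1ccc(NCc2ccc(-c3ccccc3)cc2)cc1` gives 251 nM.
Compound 2 `CN(C)Cc1ccc(CNc2ccc(CCC(=O)O)cc2)cc1` gives only a limit in this assay, < 31700 nM.
Compound 3 `O=C(O)CCc1ccc(NCc2ccc(O)cc2)cc1` likewise gives only a limit in this assay, < 31700 nM.

Compound 3 therefore stands at the edge of what this assay reports: its value is a limit, not a number, and the same holds for one of the two other values, as the limit of < 31700 nM in this assay, at which 2 of the 3 values shown sit, records. The steps that touch compound 3 cannot be sized: a step that the limit leaves unreadable from compound 1 to compound 3 and a step that the two limits leave unreadable from compound 2 to compound 3 are both left unreadable by the limits, and so is a step that the limit leaves unreadable from compound 1 to compound 2.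

Compound 4 `O=C(O)CCc1ccc(NCc2ccc(Oc3ccccc3)cc2)cc1` differs from compound 3 by phenyl in place of hydrogen on an oxygen on an aromatic ring. Going by the values given here, the only readable number among the measured compounds is that of compound 1, 251 nM, which carries a phenyl on the same arm. Compound 3, with hydroxy there, reaches only a limit. The step is thus expected to run toward smaller amounts, and its size, a step that the limit leaves unreadable from compound 3 to compound 4, is an estimate resting on compound 1 alone. Compound 4 is expected to give about 1200 nM, between 250 nM and 10000 nM.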

Compound 4, half-maximal effective concentration: 195 nM
Compound 4: middle estimate off by 6.2-fold (0.79 log units), on the high side; the whole stated range lies above it.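

Phenoxy in place of phenyl on this aromatic carbon gives, in this assay, a 1.3-fold lower number from compound 1 to compound 4 (0.11 log units; within the scatter), so the oxygen that compound 4 carries before its outer phenyl leaves it level with compound 1. The arm now has two compounds with readable numbers, both ending in a phenyl, whereas hydroxy and (dimethylamino)methyl on the same carbon give no number. The steps to compound 4 from the other two compounds cannot be read, and their size stays unknown, since each starts from a limit: the limit of < 31700 nM in this assay, at which 2 of the 4 values shown sit.

The compounds shown leave open whether a methylene or an amine could replace the oxygen of the phenoxy group with the same result. They also leave open how a fluorine or a methoxy on the outer phenyl would change the number.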